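Phenyl for methylsulfanyl: the step to compound 3

The compounds below may be only part of what the source reports. "The series", "measured", "known", "first", "only" and "open" are said of these compounds alone.

Of the compounds shown here, two have numbers so far. In a functional assay on DU-145 cells (Homo sapiens) for inhibition, read by trypan blue exclusion, with a stated time of 96 h (a lower number here means a stronger inhibitor of growth, a higher number a weaker inhibitor of growth), compound 1 (`Cc1ccc(S/C(=C/c2c[nH]c3ccccc23)C(=O)c2ccc(Br)cc2)cc1`) gives 10000 nM, and compound 2 (`CSc1ccc(/C=C(/Sc2ccc(C)cc2)C(=O)c2ccc(Br)cc2)cc1`) gives 50000 nM, the higher of the two numbers. Compound 3 (`Cc1ccc(S/C(=C/c2ccc(-c3ccccc3)cc2)C(=O)c2ccc(Br)cc2)cc1`) is not yet measured. It differs from compound 2 at one place: phenyl in place of methylsulfanyl on an aromatic carbon.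

Among the compounds with values here, the only measured step is a 5.0-fold higher number from compound 1 to compound 2 (0.70 log units; beyond the scatter). That step exchanged the whole 1H-indol-3-yl group for 4-(methylsulfanyl)phenyl, so it bears on the new change only indirectly. Within the data shown here, no measured pair exchanges methylsulfanyl itself, and the data do not fix a direction. A step no larger than the one measured is therefore expected in this assay, most likely near the scatter, with a slight lean to a lower number given that compound 2, at 50000 nM, is the higher of the two. The expected step is a 1.7-fold lower number from compound 2 to compound 3 (0.22 log units; within the scatter). For compound 3 the estimated value is 30000 nM, with an expected range of 10000 nM to 100000 nM.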

Compound 3, concentration for 50% growth inhibition: 50000 nM
Compound 3: the middle estimate sits 1.7-fold (0.22 log units) below what was measured, within the range that was stated.
By their numbers in this assay, from the lowest: compound 1; then compounds 2 and 3 (each within the scatter of the next).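

In this assay, the first exchange made at this aromatic carbon, para to a large group, gives no change at the digits printed from compound 2 to compound 3 (within the scatter), so phenyl in place of methylsulfanyl cannot be told apart from compound 2 in this read-out. Within the data shown here, the entering group has 6 heavy atoms and a six-membered aromatic ring, whereas the leaving group has 2 heavy atoms and no ring, and this difference in count and ring leaves compound 2 and compound 3 within the scatter of each other, while the only step beyond the scatter remains the exchange of the 1H-indol-3-yl group, a 5.0-fold higher number from compound 1 to compound 2 (0.70 log units; beyond the scatter). No supporting measurement accompanies this result, so the reading rests on the numbers alone.

Open, from the compounds shown here alone, is whether an amine, a carboxylic acid or a longer chain on this aromatic carbon would separate from compound 2 and compound 3 in this assay. Also open, going by these compounds, is whether a plain phenyl or a 1-methylindol-3-yl group in place of the 1H-indol-3-yl group of compound 1 would give a number close to that of compound 1, at 10000 nM, or close to that of compound 2, at 50000 nM.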